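Swapping 3-methylphenyl for 3-chloro-4-methylphenyl on the shared core

A few compounds are considered here, and "the series" means these few. Any claim that something is new, unique, unknown or untested is made for them only; others in the source may bear on it.

compound 1 `CCC1=C(O)c2c(oc(-c3ccc(C)cc3)cc2=O)C(CC)(CC)C1=O`: 39.2 uM
compound 2 `CCC1=C(O)c2c(oc(-c3ccc(CBr)cc3)cc2=O)C(CC)(CC)C1=O`: > 46.5 uM (a limit, not a number)
compound 3 `CCC1=C(O)c2c(oc(-c3cccc(C)c3)cc2=O)C(CC)(CC)C1=O`: 49.7 uM

All three readings come from a functional assay on KB cells (Homo sapiens) for antiproliferative activity, read by sulforhodamine B assay, with a stated time of 3 days; a higher number here means that more compound is needed for the effect, a lower number that less compound is needed. Going by the values given here, compound 3 lies within the scatter of compound 1, the only other compound with a true number, showing a 1.3-fold higher number from compound 1 to compound 3 (0.10 log units; within the scatter). The reading for compound 2 is a limit.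

Compound 4 `CCC1=C(O)c2c(oc(-c3ccc(C)c(Cl)c3)cc2=O)C(CC)(CC)C1=O` carries 3-chloro-4-methylphenyl in place of 3-methylphenyl on an aromatic carbon of the shared core (3-chloro-4-methylphenyl in place of 3-methylphenyl on an aromatic carbon).

Among the compounds with values here, two measured steps touch this same aromatic substituent. Exchanging 4-methylphenyl for 3-methylphenyl gave a 1.3-fold higher number from compound 1 to compound 3 (0.10 log units; within the scatter). Bromo in place of hydrogen on the saturated chain carbon bound to the aromatic carbon gave an at least 1.1-fold higher number from compound 1 to compound 2 (0.07 log units; that floor lies within the scatter), and that figure is only a floor. Within the data shown here, no measured step places a chlorine on this aromatic ring, so the expectation rests on these two neighbours alone. With compound 1 at 39.2 uM and compound 3 at 49.7 uM, no shift beyond the scatter is expected in this assay. The expected change is a 1.3-fold lower number from compound 3 to compound 4 (0.12 log units; within the scatter). Compound 4 is estimated at 38 uM, with an expected range from 18 uM to 65 uM.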

Compound 4, concentration for half-maximal effect: 39 uM
For compound 4 the middle estimate is 1.0-fold (0.01 log units) below the measured one; measured number inside the range.
By their numbers in this assay, from the lowest: compounds 4, 1 and 3 (each within the scatter of the next).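

In this assay, going by these compounds alone, compound 4 gives the first reading with a chlorine on this aromatic ring, and chloro in place of hydrogen on an aromatic carbon gives a 1.0-fold lower number from compound 1 to compound 4 (0.00 log units; within the scatter), so this addition to the 4-methylphenyl group leaves the reading within the scatter. The exchange of 3-methylphenyl for 3-chloro-4-methylphenyl gives a 1.3-fold lower number from compound 3 to compound 4 (0.11 log units; within the scatter), which places compounds 1, 3 and 4 within the scatter of one another and shows that, at this position next to the ring oxygen, none of these three aromatic groups separates from the others. The exchange of 4-(bromomethyl)phenyl for 3-chloro-4-methylphenyl gives an at least 1.1-fold lower number from compound 2 to compound 4 (0.07 log units; that floor lies within the scatter), and this is only a floor, since the reading of compound 2 is a limit: the limit of > 46.5 uM in this assay, at which 1 of the 4 values shown sits.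

The compounds shown leave open whether any group at this position can move the number beyond the scatter, since every one of them carries a phenyl ring with a methyl or bromomethyl group. An amine or a carboxylic acid on that ring, or a longer chain in place of the methyl, could answer this, as could a chlorine on the ring with no methyl beside it in the same molecule.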